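Lengthening the link to the 4-fluorophenyl group

A few compounds are considered here, and "the series" means these few. Any claim that something is new, unique, unknown or untested is made for them only; others in the source may bear on it.

Two members of the series carry numbers in a functional assay on cells (Lymphocyte, Homo sapiens); on this read-out higher numbers stand for weaker inhibition and lower numbers for stronger inhibition. Compound 1 `Nc1nc(N2CCN(C(=O)COc3ccc(Cl)cc3)CC2)c2nc(Cc3ccc(F)cc3)sc2n1` gives 700 nM in this assay, the higher of the two values seen so far; compound 2 `Nc1nc(N2CCN(C(=O)COc3ccc(Br)cc3)CC2)c2nc(-c3ccc(F)cc3)sc2n1` gives 380 nM in this assay, and the gap between these two values lies within the scatter, so neither can be ordered against the other on present numbers.

Compound 3 `Nc1nc(N2CCN(C(=O)COc3ccc(Cl)cc3)CC2)c2nc(CCCCc3ccc(F)cc3)sc2n1` has not been measured. It differs from compound 1 in a single place: 3-(4-fluorophenyl)propyl in place of 4-fluorophenyl on a saturated chain carbon bound to an aromatic carbon. Going by the values given here, no pair of measured compounds shows a change of this kind, so the series gives no reference for how the number in this assay responds to a longer link between the core and the 4-fluorophenyl group. Among the compounds with values here, with no such reference the step from compound 1 to compound 3 is expected to be small, a 1.4-fold higher number from compound 1 to compound 3 (0.15 log units; within the scatter), a slight rise that stays within the scatter, with no direction claimed beyond it. For compound 3 a value of about 1000 nM is estimated in this assay, with a broad range from 300 nM to 4000 nM.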

Compound 3, half-maximal inhibitory concentration: 920 nM
Beside the measured number, compound 3's estimate is 1.1-fold (0.04 log units) above it, within the range that was stated.
By their numbers in this assay, from the lowest: compounds 2, 1 and 3 (each within the scatter of the next, the first and the last beyond it).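

At this position the series now holds its first readable step: in this assay there is a 1.3-fold higher number from compound 1 to compound 3 (0.12 log units; within the scatter) when 3-(4-fluorophenyl)propyl stands in place of 4-fluorophenyl on a saturated chain carbon bound to an aromatic carbon. The group gains heavy atoms, all of the added atoms carbon, while the six-membered aromatic ring, the fluorine and the zero count of hydrogen-bond donors and acceptors stay the same, and in this assay this longer chain cannot be told apart from the shorter one in compound 1. No measurement shown offers an explanation for this result.

Still open, going by these compounds, is whether the number in this assay would hold if an amine or a carboxylic acid took the place of the 4-fluorophenyl group on the chain, or if the chain were longer still. Also open, on these data alone, is what the fluorine contributes at the end of this chain, a question that a plain phenyl or a 4-methoxyphenyl group would address.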